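Working notes: from compound 2 to compound 3

This account rests on a few compounds, and the source may have more. Where it says the series, first, only, none or still open, it means among the compounds named here.

Within the data shown here, compound 2 `Cc1cc(=O)n(-c2ccc(F)cc2)nc1C(=O)Nc1ccc(Oc2ncnc3[nH]ccc23)c(F)c1` is the only member of the series with a number in a functional assay on HepG2 cells (Homo sapiens) for cytotoxicity, read by MTT assay, with a stated time of 72 h (on this read-out higher numbers stand for weaker inhibition and lower numbers for stronger inhibition), where compound 2 gives 12900 nM. Compound 1 `Cc1cc(=O)n(-c2ccc(F)cc2)nc1C(=O)Nc1ccc(Oc2ncnc3[nH]ccc23)cc1` reaches only a limit of the assay in this assay, at > 60000 nM (the limit of > 60000 nM in this assay, at which 1 of the 2 values shown sits). Among the measured compounds shown here, the one measured step, an at least 4.6-fold lower number from compound 1 to compound 2 (0.66 log units; beyond the scatter), concerns fluoro in place of hydrogen on an aromatic carbon and carries no information about the other end of the molecule. Compound 3 `Cc1cc(=O)n(-c2ccccc2OC(F)(F)F)nc1C(=O)Nc1ccc(Oc2ncnc3[nH]ccc23)c(F)c1` differs from compound 2 by 2-(trifluoromethoxy)phenyl in place of 4-fluorophenyl on an aromatic nitrogen. For the measured compounds named here, no measured step touches this position, so the series gives no basis for a direction; the expected step is a 1.1-fold lower number from compound 2 to compound 3 (0.03 log units; within the scatter), within the scatter. Compound 3 is therefore estimated at 12000 nM in this assay, with a range from 3000 nM to 50000 nM, and a real chance that only a limit is reported.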

Compound 3, half-maximal inhibitory concentration: > 60000 nM
Compound 3: no number, only a limit; the forecaster's own chance of this, stated with the estimate: 25%; middle value at least 5.0-fold (0.69 log units) from the limit.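

In this assay, among these compounds, the group on the aromatic nitrogen proves to matter: 2-(trifluoromethoxy)phenyl in place of 4-fluorophenyl gives an at least 4.6-fold higher number from compound 2 to compound 3 (0.66 log units; beyond the scatter) and is the first measured step at this end of the molecule. Compound 3 reaches only a limit of the assay, so the step has a bound but no exact size: the limit of > 60000 nM in this assay, at which 2 of the 3 values shown sit. Compound 3 keeps the fluoro that separates compound 2 from compound 1, yet with the new group on the aromatic nitrogen no number is obtained.

From the compounds shown here alone, it remains open whether this follows from the trifluoromethoxy group itself or from its place on the phenyl ring, and a 2-methoxyphenyl or 4-(trifluoromethoxy)phenyl group would help separate the two. Also open, going by these compounds, is how an amine or a carboxylic acid on that phenyl ring would read.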